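The compounds below may be only part of what the source reports. "The series", "measured", "known", "first", "only" and "open" are said of these compounds alone.

In a functional assay on HeLa cells (Homo sapiens) for inhibition, read by CCK-8 assay, with a stated time of 72 h, tested at 8 uM (a higher number here means more inhibition of growth at the concentration tested, a lower number less inhibition of growth), compound 1 `Nc1ccccc1NC(=O)/C=C/c1ccc(CSc2ccc(Cl)cc2)cc1` gives 17.3% and compound 2 `CCc1ccc(SCc2ccc(/C=C/C(=O)Nc3ccccc3N)cc2)cc1` gives 20.9%, so these two values lie within the scatter of each other. Compound 3 `Nc1ccccc1NC(=O)/C=C/c1ccc(CSc2ccc(C(F)(F)F)cn2)cc1` has 5-(trifluoromethyl)pyridin-2-yl in place of 4-ethylphenyl on a sulfur. Within the data shown here, the only measured step, a number 3.6 percentage points higher from compound 1 to compound 2 (within the scatter), stayed within the scatter, but it exchanged just ethyl and chloro, whereas here the whole group on the sulfur changes. It is therefore a weak guide, and no step beyond the scatter is expected in this assay. The estimated change is a number 0.9 percentage points lower from compound 2 to compound 3 (within the scatter). For compound 3 the expected value is 20%, within an estimated range of 8% to 36%.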

Compound 3, percent growth inhibition at one concentration: 6.82%
Estimate against measurement, compound 3: 13.2 percentage points above; measured number below the stated range.
By their numbers in this assay, from the lowest: compound 3; then compounds 1 and 2 (each within the scatter of the next).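

The group on the sulfur does matter in this assay: a number 14.1 percentage points lower from compound 2 to compound 3 (beyond the scatter), and a number 10.5 percentage points lower from compound 1 to compound 3 (beyond the scatter), whereas ethyl in place of chloro gave only a step within the scatter. Growth inhibition falls when 5-(trifluoromethyl)pyridin-2-yl replaces either 4-ethylphenyl or 4-chlorophenyl. No measured evidence here explains this drop.

As far as these compounds go, the ring nitrogen and the trifluoromethyl group enter together, so their separate contributions remain unknown. A 4-(trifluoromethyl)phenyl group or an unsubstituted pyridin-2-yl group on the sulfur would tell them apart.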